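Benzyl replacing 4-fluorophenyl on a hydantoin Mannich base

The source may hold more compounds than are shown below. What is called first, only, known or untested is meant among the compounds shown, and "the series" means these compounds.

Measured so far:
compound 1, `CC(C)C1(C(C)C)NC(=O)N(CN2CCN(c3ccc(F)cc3)CC2)C1=O`, 100 mg/kg
compound 2, `O=C1NC(c2ccccc2)(c2ccccc2)C(=O)N1CN1CCN(c2ccc(F)cc2)CC1`, 100 mg/kg

Both compounds were tested in a functional assay on the whole organism (strain CD1) with Mus musculus as the target, in the maximal electroshock model, with a stated time of 4 h; on this read-out lower numbers stand for an effect already at smaller amounts and higher numbers for an effect only at larger amounts of compound. Compound 2 gives 100 mg/kg in this assay, and compound 1 gives 100 mg/kg, so the two stand level at the digits shown, within the scatter of repeated measurements. For the measured compounds named here, no step between measured compounds is available, so nothing yet shows how a change on the amine nitrogen in the ring moves the read-out.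

Compound 3, `O=C1NC(c2ccccc2)(c2ccccc2)C(=O)N1CN1CCN(Cc2ccccc2)CC1`, has not been measured. It differs from compound 2 in one place: benzyl in place of 4-fluorophenyl on an amine nitrogen in a ring.

Going by the values given here, with no measured step to rest on, the expectation for compound 3 in this assay is a step of no change at the digits printed from compound 2 to compound 3 (within the scatter) from compound 2, that is, no change beyond the scatter. Compound 3 is thus estimated at 100 mg/kg, within a range from 50 mg/kg to 300 mg/kg.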

Compound 3, minimum effective dose: 100 mg/kg
Beside the measured number, compound 3's estimate shows no gap at the digits printed; the measured number falls inside the stated range.
By their numbers in this assay, from the lowest: compounds 1, 2 and 3 (each within the scatter of the next).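

For the compounds shown here, this is the first step read at this position: in this assay, putting benzyl in place of 4-fluorophenyl on the amine nitrogen in a ring gives no change at the digits printed from compound 2 to compound 3 (within the scatter). The two groups each carry one six-membered aromatic ring of carbon only, so this position tolerates this particular exchange on the core of compound 2 without a visible shift in the read-out. Nothing available explains why the two groups read alike.

Still open, as far as these compounds go, is whether the same holds for groups of a different kind on that nitrogen, such as an acetyl group, a simple methyl or a longer chain like 3-phenylpropyl. Also open, from the compounds shown here alone, is whether benzyl behaves the same way on the core of compound 1.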